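Isopropyl for cyclobutyl at the sulfonamide nitrogen arm

The source may report more compounds than this note shows. Statements on the series, on what has been measured and on what is new or still open speak of the compounds shown alone.

Measured compounds:
- compound 1 `CCc1ccc(N(CC2CCC2)S(=O)(=O)c2ccc3c(c2)C(=O)CC(C2CCOCC2)O3)cc1`: 4.1
- compound 2 `CCc1ccc(N(CC(C)C)S(=O)(=O)c2ccc3c(c2)C(F)CC(C2CCOCC2)O3)cc1`: 5.02
- compound 3 `CCc1ccc(N(CC(C)C)S(=O)(=O)c2ccc3c(c2)C(=O)CC(C2CCN(S(=O)(=O)C4CCCC4)CC2)O3)cc1`: 4.75

All three compounds were measured in a physicochemical assay for lipophilicity, at pH 7.4; a higher number here means a more lipophilic compound, a lower number a more polar compound. Compound 1 gives the lowest of the three numbers. The nearest of the other two is compound 3, which stands higher by a gap beyond the scatter, and the furthest is compound 2, which stands higher still, also beyond the scatter. Among the measured compounds shown here, no two of the measured compounds differ in one place only, so no single step among them can be read directly.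

Compound 4 `CCc1ccc(N(CC(C)C)S(=O)(=O)c2ccc3c(c2)C(=O)CC(C2CCOCC2)O3)cc1` has not yet been measured in this assay. It differs from compound 1 in one place: isopropyl in place of cyclobutyl on a saturated chain carbon bound to a sulfonamide nitrogen. For the measured compounds named here, with no measured step of this kind on record, the size of the change has to be estimated from the structural change alone. The step from compound 1 to compound 4 is expected to be a small downward one, a number 0.25 log units lower from compound 1 to compound 4 (within the scatter), close to the edge of the scatter and possibly not separable from it. On that basis compound 4 is expected to give 3.85, with a range from 3.4 to 4.3.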

Compound 4, distribution coefficient: 4.21
Compound 4: the middle estimate sits 0.36 log units below what was measured, and the stated range covers the measured number.
By their numbers in this assay, from the lowest: compounds 1 and 4 (each within the scatter of the next); then compounds 3 and 2 (each within the scatter of the next).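

Among the compounds shown here, compound 4 gives this position its one readable step in this assay: isopropyl in place of cyclobutyl, on a saturated chain carbon bound to a sulfonamide nitrogen, comes to a number 0.11 log units higher from compound 1 to compound 4 (within the scatter). Opening the cyclobutylmethyl arm into the isobutyl arm, with the ring gone and one carbon fewer, therefore leaves compound 1 and compound 4 indistinguishable in this read-out, something the earlier compounds could not show, as none of them differed from another in one place only. No other evidence bears on this result, so it stands as an observation without an explanation.

The compounds shown leave open how far this tolerance extends, as an amine, a carboxylic acid or a longer chain at the same place could behave quite differently from these two hydrocarbon arms. For the compounds shown here, they also leave open whether the same change would give a similar step on the other parts of the molecule seen in compound 2 and compound 3, each of which carries the isobutyl arm but has no cyclobutylmethyl partner, so that no step to either can be read.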